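The source may hold more compounds than are shown below. What is called first, only, known or untested is meant among the compounds shown, and "the series" means these compounds.

Measured compounds:
- compound 1, `CC#CC(CC(=O)O)c1ccc(OCc2ccc(C(=O)N3CCc4ccccc4C3)s2)cc1`, in a functional assay on HEK293 cells for agonist activity at Free fatty acid receptor 1 (Homo sapiens), read by fluorescence and calcium flux (on this read-out lower numbers stand for an effect already at smaller amounts and higher numbers for an effect only at larger amounts of compound), compound 1 gives 57 nM
- compound 2, `CC#CC(CC(=O)O)c1ccc(OCc2ccc(C(=O)NC3CCCc4ccccc43)s2)cc1`, in this assay compound 2 gives 109 nM
- compound 3, `CC#CC(CC(=O)O)c1ccc(OCc2ccc(C(=O)N3CCc4ccccc4C3)o2)cc1`, in this assay compound 3 gives 50 nM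

Compounds 1 and 2 share one core, and compound 3 sits on a second core; how the two cores differ is not broken down here. Compound 4, `CC#CC(CC(=O)O)c1ccc(OCc2ccc(C(=O)NC3CCCc4ccccc43)o2)cc1`, has not been measured and carries the second core.

Within the first core a single change has been measured: (1,2,3,4-tetrahydronaphthalen-1-yl)amino in place of 1,2,3,4-tetrahydroisoquinolin-2-yl on a carbonyl carbon. This change made the step of a 1.9-fold higher number from compound 1 to compound 2 (0.28 log units; within the scatter), so the two compounds lie within the usual scatter of each other and no order between them can be read from their values. Compound 3 stands nearest to compound 1 and furthest from compound 2, with the latter gap lying beyond the scatter.

The same change is now made on the second core, from compound 3 to compound 4: (1,2,3,4-tetrahydronaphthalen-1-yl)amino in place of 1,2,3,4-tetrahydroisoquinolin-2-yl on a carbonyl carbon. The carbonyl carbon that carries the change has the same neighbours in both pairs, so this is the same change on a different core. Because the measured pair gave a 1.9-fold higher number from compound 1 to compound 2 (0.28 log units; within the scatter), the step for compound 4 is expected to be of a similar modest size, estimated as a 1.9-fold higher number from compound 3 to compound 4 (0.28 log units; within the scatter). On this basis compound 4 is expected to give about 95 nM in this assay, with a likely range estimated from 45 nM to 200 nM.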

Compound 4, half-maximal effective concentration: 133 nM
Compound 4: the middle estimate sits 1.4-fold (0.15 log units) below what was measured; measured number inside the range.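

On the second core, (1,2,3,4-tetrahydronaphthalen-1-yl)amino in place of 1,2,3,4-tetrahydroisoquinolin-2-yl on the carbonyl carbon gives a 2.7-fold higher number from compound 3 to compound 4 (0.42 log units; beyond the scatter) in this assay. Set beside the step on the first core, this step cannot be told apart from it, so in these two pairs the change carries over from one core to the other with a step of comparable size: the same change on two cores in this assay, a 1.9-fold higher number (0.28 log units; within the scatter) from compound 1 to compound 2 and a 2.7-fold higher number (0.42 log units; beyond the scatter) from compound 3 to compound 4, 1.4-fold (0.14 log units) apart, within the scatter of two such steps This does not show that the change would behave alike on any other core in the series, since it rests on two pairs in a single assay, and only the step on the second core lies beyond the scatter when taken alone.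

The compounds shown leave open whether the amide hydrogen that enters with the change has any part in the step, which a methyl group in place of that hydrogen could help to separate from the change of ring. They also leave open whether the step would stay the same if the carboxylic acid, which all four compounds keep, gave way to a tetrazole.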